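The source may hold more compounds than are shown below. What is called first, only, known or untested is meant among the compounds shown, and "the series" means these compounds.

Values so far in a functional assay on A549 cells (Homo sapiens) for inhibition, read by sulforhodamine B assay, with a stated time of 72 h (a lower number here means a stronger inhibitor of growth, a higher number a weaker inhibitor of growth), are all limits:
- compound 1 `CN1CCN(C(=O)/C=C/c2ccncc2-c2ccc3ccccc3c2)CC1` gives > 10000 nM as a limit
- compound 2 `NNC(=O)CCc1ccncc1-c1ccc2ccccc2c1` gives > 10000 nM as a limit
- compound 3 `O=C(O)/C=C/c1ccncc1-c1ccc2ccccc2c1` gives > 10000 nM as a limit

Compound 3 has only the limit > 10000 nM and no number. Among the measured compounds shown here, the series so far shows the limit of > 10000 nM in this assay, at which 3 of the 3 values shown sit, and nothing finer.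

Compound 4 `CNC(=O)CCc1ccncc1-c1ccc2ccccc2c1` carries 2-(methylcarbamoyl)ethyl in place of 2-carboxyethenyl on an aromatic carbon, opposite the ring nitrogen, with the count 2-(methylcarbamoyl)ethyl in place of 2-carboxyethenyl on an aromatic carbon as the full difference.

For the measured compounds named here, two measured steps bear on this change, a step that the two limits leave unreadable from compound 2 to compound 3 and a step that the two limits leave unreadable from compound 1 to compound 3, and neither gives a size. Compound 2, with 2-(aminocarbamoyl)ethyl at that place, stays at the limit > 10000 nM and gives no number. Compound 1, an amide on the carbonyl carbon, stays at the limit > 10000 nM and gives no number.

No step beyond the scatter is therefore expected in this assay in either direction, and the expected step is a number no higher from compound 3 to compound 4 (the limit leaves the size open) with a limit as the likeliest report. Compound 4 is estimated at 10000 nM with an expected range from 5000 nM to 20000 nM.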

Compound 4, concentration for 50% growth inhibition: 10400 nM
Compound 4: the middle estimate sits 1.0-fold (0.02 log units) below what was measured, within the range that was stated.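

In this assay no new step can be read: compound 4 can be set only against limits at compound 2 and compound 3, so neither size is readable. The compounds shown leave open how far any change at this place shifts growth inhibition: the limit of > 10000 nM in this assay, at which 3 of the 4 values shown sit.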